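A few compounds are considered here, and "the series" means these few. Any claim that something is new, unique, unknown or untested is made for them only; others in the source may bear on it.

Compound 1 `CCN(Cc1cccs1)C(=O)COc1ccc(C(=O)O)cc1` carries a carboxy group on its six-membered aromatic ring of carbon only, and in an assay on HEK293 cells for agonist activity at transient receptor potential cation channel subfamily M member 8 (Homo sapiens), read by fluorescence and calcium flux, with a stated time of 15 min (a higher number here means that more compound is needed for the effect, a lower number that less compound is needed), compound 1 is reported as "not active" (no number reported), so no single number marks where it stands; it simply gave no measurable effect. A second, differently built compound offers some orientation: compound 2 `Cc1ccc(OCC(=O)N(Cc2cccs2)c2ncccn2)cc1` does yield a number, since in this assay compound 2 gives 3700 nM. The two results cannot be set side by side as a step, but they show that compounds of this general kind can register an effect, while compound 1 did not.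

The change to compound 3 `CCN(Cc1cccs1)C(=O)COc1ccc(CO)cc1` is small and confined to one place: hydroxymethyl in place of carboxy on an aromatic carbon. Both the group that leaves and the group that enters can donate and accept a hydrogen bond, but only the carboxy group can carry a charge in solution. Going by the values given here, since compound 1 has no number at all, no size of step can be stated; the question is only whether compound 3 produces a measurable effect. It is expected that compound 3 registers weakly, around 8000 nM, with a likely range from 2000 nM to 40000 nM, and a real chance that again only a limit is reported.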

Compound 3, half-maximal effective concentration: 21900 nM
The estimate for compound 3 lay 2.7-fold (0.44 log units) below the measured number, within the range that was stated.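

No step can be read between compound 1 and compound 3: in this assay compound 1 has no number, while compound 3 gives 21900 nM as a single value. Nothing measured here explains this result. The compounds shown leave open how large the effect of exchanging carboxy for hydroxymethyl really is.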